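Hydroxycyclobutyl to Methoxycyclohexyl Where Both Starting Points Are Limits

The compounds below may be only part of what the source reports. "The series", "measured", "known", "first", "only" and "open" are said of these compounds alone.

Compound 1 `N#Cc1cnc(NCc2cnccc2C(F)(F)F)cc1N[C@H]1C[C@H](O)C1` and compound 2 `N#Cc1cnc(NCc2cnccc2C(F)(F)F)cc1NC[C@H]1C[C@H](O)C1` share a core and were both tested in an assay on isolated protein for inhibition of protein kinase C delta type (Homo sapiens), read by TR-FRET, with a stated time of 2 h; a lower number here means a stronger inhibitor, a higher number a weaker inhibitor. For compound 1 the assay reports only a limit, > 10000 nM. For compound 2 the result is likewise a limit, > 10000 nM. The step that the two limits leave unreadable from compound 1 to compound 2 cannot be read, since both of its ends sit at the same limit, as the limit of > 10000 nM in this assay, at which 2 of the 2 values shown sit, records. Compound 2 therefore stands at the limit of this assay, with no number of its own.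

Compound 3 `CO[C@H]1CC[C@@H](CNc2cc(NCc3cnccc3C(F)(F)F)ncc2C#N)CC1` is compound 2 with one group exchanged: 4-methoxycyclohexyl in place of 3-hydroxycyclobutyl on a saturated chain carbon bound to a nitrogen on an aromatic ring. Within the data shown here, the only measured step, a step that the two limits leave unreadable from compound 1 to compound 2, is the one that bears on this change, and it gives no size and no direction. With nothing readable to build on, compound 3 is expected to come back at the limit as well, and its estimate in this assay is 15000 nM, within a range from 3000 nM to 60000 nM. The expected step that the limit leaves unreadable from compound 2 to compound 3 is accordingly no change that could be told from the scatter.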

Compound 3, half-maximal inhibitory concentration: 5000 nM
Compound 3: middle estimate off by 3.0-fold (0.48 log units), on the high side; low and high end bracket the measured number.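

Compound 3 is the only one of the three with a number of its own in this assay, 5000 nM, so this position can carry a group that gives a reading in this range. Exchanging the group gives an at least 2.0-fold lower number from compound 2 to compound 3 (0.30 log units; that floor lies within the scatter), and the comparison with the other limit compound gives an at least 2.0-fold lower number from compound 1 to compound 3 (0.30 log units; that floor lies within the scatter); each step starts from a limit, so these are floors, the true sizes stay unread, and neither floor by itself lies beyond the scatter. What is new is therefore a reading rather than a measured size of gain, set against the limit that holds the other two compounds: the limit of > 10000 nM in this assay, at which 2 of the 3 values shown sit.

The change swaps the four-membered ring for a six-membered one and the hydroxyl for a methoxy group together, and the compounds shown do not tell which of these goes with the reading for compound 3. As far as these compounds go, a 4-hydroxycyclohexyl or a 3-methoxycyclobutyl group on a saturated chain carbon bound to a nitrogen on an aromatic ring would separate the two, and whether a number well under that of compound 3 can be reached here remains open.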